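Working notes: fluoro in place of ethyl, compound 4

The source may report more compounds than this note shows. Statements on the series, on what has been measured and on what is new or still open speak of the compounds shown alone.

Compound 1 `Cc1cc(NC(=O)Nc2ccc(C)c(Cl)c2)c2ccccc2n1`: > 25000 nM
Compound 2 `CCc1ccc(NC(=O)Nc2cc(C)nc3ccccc23)cc1`: > 25000 nM
Compound 3 `COc1ccc(NC(=O)Nc2cc(C)nc3ccccc23)cc1OC`: > 25000 nM

The read-out here is an ADME assay on BJ cells (Homo sapiens) for cytotoxicity, with a stated time of 72 h; on this read-out higher numbers stand for an effect only at larger amounts of compound and lower numbers for an effect already at smaller amounts. Each entry above is a limit of the assay and not a number. In this read-out compound 2 gives > 25000 nM, which is a limit. It shares its standing with the other two measured compounds: the limit of > 25000 nM in this assay, at which 3 of the 3 values shown sit. Among the measured compounds shown here, no pair of measured compounds offers a step with a number.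

Compound 4 `Cc1cc(NC(=O)Nc2ccc(F)cc2)c2ccccc2n1` differs from compound 2 at one place: fluoro in place of ethyl on an aromatic carbon. This is fluoro in place of ethyl on an aromatic carbon, para to a large group.

In this assay no step beyond the scatter is expected, and so no direction. That expectation rests on compound 2, whose > 25000 nM is a limit, and on the same limit for compounds 1 and 3. The estimated step of a number no higher from compound 2 to compound 4 (the limit leaves the size open) is expected to stay within the scatter. For compound 4 the estimate is 25000 nM, with an expected range of 12000 nM to 50000 nM.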

Compound 4, half-maximal effective concentration: > 25000 nM
Compound 4 ended at the assay's limit; the forecaster's own chance of this, stated with the estimate: 85%; the middle value lies on the limit itself.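

In this assay, among the compounds shown here, no step from compound 2 to compound 4 can be read, because both end at a limit and not at a number: the limit of > 25000 nM in this assay, at which 4 of the 4 values shown sit. The compounds shown leave open how far each lies from that limit, and whether any change in the series shifts the read-out.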